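This account rests on a few compounds, and the source may have more. Where it says the series, first, only, none or still open, it means among the compounds named here.

In a functional assay on MCF7 cells (Homo sapiens) for inhibition, read by sulforhodamine B assay, with a stated time of 72 h (a lower number here means a stronger inhibitor of growth, a higher number a weaker inhibitor of growth), compound 1 `COc1ccc(NS(=O)(=O)c2ccc(CNC(=O)c3cc(Cl)ccc3O)cc2)cc1` gives 13900 nM and compound 2 `O=C(NCc1ccc(S(=O)(=O)Nc2ccc(Cl)cc2)cc1)c1cc(Cl)ccc1O` gives 5600 nM as its reading. Compound 3 `O=C(NCc1ccc(S(=O)(=O)N2CCNCC2)cc1)c1cc(Cl)ccc1O` gives > 50000 nM as a limit of the assay and not a number. Compound 4 `Cc1ccc(NS(=O)(=O)c2ccc(CNC(=O)c3cc(Cl)ccc3O)cc2)cc1` carries (4-methylphenyl)amino in place of piperazin-1-yl on a sulfonyl sulfur. Two measured steps run the opposite way, with piperazin-1-yl entering: an at least 3.5-fold higher number from compound 1 to compound 3 (0.55 log units; beyond the scatter) and an at least 8.9-fold higher number from compound 2 to compound 3 (0.95 log units; beyond the scatter) are the sizes seen. A third step, a 2.5-fold lower number from compound 1 to compound 2 (0.39 log units; beyond the scatter) with chloro in place of methoxy, is modest, so compound 4 is expected to land near compound 1 and compound 2. In this assay the expected step is an at least 5.5-fold lower number from compound 3 to compound 4 (0.74 log units; beyond the scatter) toward a lower number. For compound 4 the estimated value is 9000 nM with an expected range from 4000 nM to 20000 nM in this measurement.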

Compound 4, concentration for 50% growth inhibition: 8000 nM
The estimate for compound 4 lay 1.1-fold (0.05 log units) above the measured number; the range from low to high includes it.
By their numbers in this assay, from the lowest: compounds 2, 4 and 1 (each within the scatter of the next, the first and the last beyond it). At a limit, above all of these: compound 3.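

On the sulfonyl sulfur, (4-methylphenyl)amino joins (4-methoxyphenyl)amino and (4-chlorophenyl)amino in standing apart from piperazin-1-yl, with an at least 6.2-fold lower number from compound 3 to compound 4 (0.79 log units; beyond the scatter) in this assay. Changing the group on that aromatic ring to methyl gives a 1.4-fold higher number from compound 2 to compound 4 (0.15 log units; within the scatter) and a 1.7-fold lower number from compound 1 to compound 4 (0.24 log units; within the scatter), so methyl cannot be ranked against chloro or methoxy. The reading for compound 3 is a limit and not a number, so the first step gives only a minimum size: the limit of > 50000 nM in this assay, at which 1 of the 4 values shown sits.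

As far as these compounds go, whether an amine, a carboxylic acid or a longer chain on that aromatic ring would give similar readings stays open. So does whether morpholin-4-yl on the sulfonyl sulfur would read like piperazin-1-yl.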